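This account rests on a few compounds, and the source may have more. Where it says the series, first, only, none or still open, it means among the compounds named here.

Compound 1 `CCCc1cc(N)c2cc(NC(=O)CCc3ccccc3)ccc2n1` gives 8300 nM in an assay on isolated protein for displacement of a labelled ligand from melanin-concentrating hormone receptor 1 (Homo sapiens); a lower number here means a stronger inhibitor, a higher number a weaker inhibitor.
Compound 2 `CCCc1cc(N)c2cc(NC(=O)/C=C/c3ccc(N)cc3)ccc2n1` gives 190 nM in this assay.
Compound 3 `CCCc1cc(N2CCCC2)c2cc(NC(=O)/C=C/c3ccc(C(F)(F)F)cc3)ccc2n1` gives 17 nM in this assay.

Compound 3 stands lowest of the three numbers; the nearest, compound 2, lies beyond the scatter above it, and compound 1 lies furthest above. Compound 4 `CCCc1cc(N2CCCCC2)c2cc(NC(=O)/C=C/c3ccc(C(F)(F)F)cc3)ccc2n1` differs from compound 3 in one place: piperidin-1-yl in place of pyrrolidin-1-yl on an aromatic carbon. Among the measured compounds shown here, no pair of measured compounds that differ in one place is available here, so nothing directly shows what such a change does in this assay. Compound 4 is therefore expected to stay close to compound 3, with a step of a 1.2-fold higher number from compound 3 to compound 4 (0.07 log units; within the scatter) that need not exceed the scatter. The estimate for compound 4 in this assay is 20 nM, within a range from 7 nM to 60 nM.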

Compound 4, half-maximal inhibitory concentration: > 4000 nM
Compound 4: no number, only a limit; the forecaster's own chance of this, stated with the estimate: 0%; middle value at least 200-fold (2.30 log units) away from the limit.
By their numbers in this assay, from the lowest: compound 3; then compound 2; then compound 1.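

Among the compounds shown here, the step is the first direct reading at this position, since the earlier compounds held no pair differing in one place. In this assay, a six-membered piperidin-1-yl ring in place of the five-membered pyrrolidin-1-yl ring, opposite the ring nitrogen, brings an at least 230-fold higher number from compound 3 to compound 4 (2.37 log units; beyond the scatter). Compound 4 carries a limit of the assay and not a number, so the full size of the step stays unknown: the limit of > 4000 nM in this assay, at which 1 of the 4 values shown sits.

Still open, as far as these compounds go, is how a dimethylamino group, an azetidin-1-yl ring or a morpholin-4-yl ring would read at this position. From the compounds shown here alone, it is also open whether the same swap gives a similar step with the amino group in place of trifluoromethyl.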